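This account rests on a few compounds, and the source may have more. Where it says the series, first, only, none or still open, it means among the compounds named here.

Compound 1, `Cc1cc(C)c(NC(=O)N(Cc2ccc(-c3ccn(C)n3)cc2)C2CCCCCC2)c(C)c1`: 44 nM
Compound 2, `Cc1cc(C)c(NC(=O)N(Cc2ccc(-n3cncn3)cc2)C2CCCCCC2)c(C)c1`: 26 nM

For the measured compounds named here, in an assay on microsomes from intestine for inhibition of acyl-CoA:cholesterol acyltransferase (Oryctolagus cuniculus) (on this read-out lower numbers stand for stronger inhibition and higher numbers for weaker inhibition), compound 2 sits at the lower end of the two numbers so far, yet the single step connecting them, a 1.7-fold lower number from compound 1 to compound 2 (0.23 log units; within the scatter), is within the scatter, so compound 1 and compound 2 cannot be told apart on this read-out. Compound 3, `Cc1cc(C)c(NC(=O)N(Cc2ccc(-n3ccnn3)cc2)C2CCCCCC2)c(C)c1`, differs from compound 2 by 1H-1,2,3-triazol-1-yl in place of 1H-1,2,4-triazol-1-yl on an aromatic carbon. Going by the values given here, only one measured step bears on it: the exchange of one small aromatic heterocycle for another at the same place on the shared core, which moved the number only within the scatter. Another exchange of the same kind is therefore expected to leave this assay essentially unchanged. Compound 3 is expected to give about 30 nM, within a range of 12 nM to 75 nM, which corresponds to an estimated step of a 1.2-fold higher number from compound 2 to compound 3 (0.06 log units; within the scatter).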

Compound 3, half-maximal inhibitory concentration: 42 nM
Compound 3: middle estimate off by 1.4-fold (0.15 log units), on the low side; the range from low to high includes it.
By their numbers in this assay, from the lowest: compounds 2, 3 and 1 (each within the scatter of the next).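

Compound 2 and compound 3 carry the same atoms joined differently, and in this assay this exchange of 1H-1,2,4-triazol-1-yl for 1H-1,2,3-triazol-1-yl gives a 1.6-fold higher number from compound 2 to compound 3 (0.21 log units; within the scatter) and so cannot be told apart from no change. The exchange of 1-methyl-1H-pyrazol-3-yl for 1H-1,2,3-triazol-1-yl gives a 1.0-fold lower number from compound 1 to compound 3 (0.02 log units; within the scatter) as well, so all three five-membered aromatic rings, placed para to a large group on the shared core, read alike on this assay. No evidence at hand accounts for this sameness.

The compounds shown leave open whether this place stays equally undemanding for groups of another kind, such as a morpholine, a carboxylic acid or a plain methyl group. They also leave open whether a larger group here, such as a fused bicyclic ring, would give a step beyond the scatter.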